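Adding a Chloro Group to the Iodo Compound

The source may hold more compounds than are shown below. What is called first, only, known or untested is meant among the compounds shown, and "the series" means these compounds.

In a functional assay on 786-0 cells (Homo sapiens) for inhibition, read by sulforhodamine B assay, with a stated time of 48 h (on this read-out higher numbers stand for weaker inhibition of growth and lower numbers for stronger inhibition of growth), compound 1 `NC(=O)c1cc(Br)ccc1NC(=O)/C=C/c1ccccc1` gives 1760 nM and compound 2 `NC(=O)c1cc(I)ccc1NC(=O)/C=C/c1ccccc1` gives 1430 nM on the same scale, so the two stand level and neither can be ranked above the other. Among the compounds with values here, the only measured step is a 1.2-fold lower number from compound 1 to compound 2 (0.09 log units; within the scatter) for iodo in place of bromo on an aromatic carbon. Compound 3 `NC(=O)c1cc(I)ccc1NC(=O)/C=C/c1ccccc1Cl` keeps the iodo group and adds one new change, phenyl to 2-chlorophenyl (chloro in place of hydrogen on an aromatic carbon), which is chloro in place of hydrogen on an aromatic carbon, ortho to a large group. Within the data shown here, no measured compound tests a change at this place, so the data give no direction. Among the measured compounds shown here, with a 1.2-fold lower number from compound 1 to compound 2 (0.09 log units; within the scatter) as the sole and loose guide, no step beyond the scatter is expected in this assay for this change. Compound 3 is therefore estimated at 1300 nM (expected range 500 nM to 3400 nM). This estimate means a 1.1-fold lower number from compound 2 to compound 3 (0.04 log units; within the scatter) as the expected step.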

Compound 3, concentration for 50% growth inhibition: 937 nM
The estimate for compound 3 lay 1.4-fold (0.14 log units) above the measured number, and the stated range covers the measured number.
By their numbers in this assay, from the lowest: compounds 3, 2 and 1 (each within the scatter of the next).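

Within the data shown here, this is the first measured change on the phenyl ring of the series: chloro in place of hydrogen on an aromatic carbon, ortho to a large group. In this assay it gives a 1.5-fold lower number from compound 2 to compound 3 (0.18 log units; within the scatter), so compound 2 and compound 3 stand level, and this position carries the added chlorine atom with no change that can be told from the scatter. No measurement shown here gives a reason for this result.

From the compounds shown here alone, whether fluoro, methoxy, an amine or a carboxylic acid in place of the chloro would give a step beyond the scatter remains open. Also open, going by these compounds, is whether the same chloro group would behave alike with bromo in place of iodo, as in compound 1.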